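Hydrazone Variation on a Shared Core: Toward Compound 4

This account rests on a few compounds, and the source may have more. Where it says the series, first, only, none or still open, it means among the compounds named here.

Compound 1, `CCCSc1nc(N/N=C/c2ccc(C)cc2)c2nnn(Cc3ccccc3)c2n1`, in a functional assay on MCF7 cells (Homo sapiens) for antiproliferative activity, read by MTT assay, with a stated time of 72 h (a lower number here means a stronger inhibitor, a higher number a weaker inhibitor), gives only a limit, > 64000 nM.
Compound 2, `CCCSc1nc(N/N=C/c2ccc(Cl)cc2)c2nnn(Cc3ccccc3)c2n1`, in this assay gives only a limit, > 64000 nM.
Compound 3, `CCCSc1nc(N/N=C/c2cccs2)c2nnn(Cc3ccccc3)c2n1`, in this assay gives only a limit, > 64000 nM.

The three measured compounds share one core and differ only in the group on the carbon with a double bond to nitrogen. None of the three gives a number: all sit at the limit of > 64000 nM in this assay, at which 3 of the 3 values shown sit. The steps among them are therefore not readable: a step that the two limits leave unreadable from compound 1 to compound 2, a step that the two limits leave unreadable from compound 1 to compound 3 and a step that the two limits leave unreadable from compound 2 to compound 3. Compound 3 thus stands where the other two stand, at a limit and not at a number.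

Compound 4, `CCCSc1nc(N/N=C/c2c[nH]c3ccccc23)c2nnn(Cc3ccccc3)c2n1`, carries the change (1H-indol-3-yl in place of thiophen-2-yl on a carbon with a double bond to nitrogen). For the measured compounds named here, the steps that bear on it are the two into compound 3, a step that the two limits leave unreadable from compound 1 to compound 3 and a step that the two limits leave unreadable from compound 2 to compound 3, both unreadable, so no size or direction can be drawn from them for this assay. With every measured value at the limit, compound 4 is expected to remain there as well, and the step of a number no higher from compound 3 to compound 4 (the limit leaves the size open) is estimated to be none that the numbers could show. For compound 4 the estimate in this assay is 64000 nM, with a range from 20000 nM to 200000 nM.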

Compound 4, half-maximal inhibitory concentration: 9010 nM
Beside the measured number, compound 4's estimate is 7.1-fold (0.85 log units) above it; measured number below the stated range.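

For the compounds shown here, with 1H-indol-3-yl on the carbon with a double bond to nitrogen, the series gains its only readable number in this assay, so this position can now be seen to respond to the group it carries, which the earlier compounds could not show. Going by these compounds alone, measured against the limits of the earlier compounds, the change gives an at least 7.1-fold lower number from compound 3 to compound 4 (0.85 log units; beyond the scatter), and replacing the other two groups gives an at least 7.1-fold lower number from compound 2 to compound 4 (0.85 log units; beyond the scatter) and an at least 7.1-fold lower number from compound 1 to compound 4 (0.85 log units; beyond the scatter). The steps among compound 1, compound 2 and compound 3 still cannot be read, and these three remain together: the limit of > 64000 nM in this assay, at which 3 of the 4 values shown sit.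

In going from thiophen-2-yl to 1H-indol-3-yl, the change brings in both a hydrogen-bond donor and a six-membered aromatic ring of carbon only, and the compounds shown do not separate the two; a 1-methyl-1H-indol-3-yl group or a naphthyl group on the same carbon would bear on that question. Also open, as far as these compounds go, is whether the step holds on a changed core, for instance with a longer chain in place of the propyl chain or with an amine in place of the propylsulfanyl group.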